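The source may hold more compounds than are shown below. What is called first, only, known or untested is meant among the compounds shown, and "the series" means these compounds.

Of the compounds shown here, three with a shared core have been measured in an ADME assay on HEK293 cells (Homo sapiens) for cytotoxicity, read by sulforhodamine B assay, with a stated time of 48 h, tested at 10 uM; a lower number here means less inhibition, a higher number more inhibition at the concentration tested (going by the name of the read-out). Compound 1 `CCCCc1cn(C(c2ccccc2)c2cc3cc(Br)ccc3nc2OC)nn1` gives -3.47%, compound 2 `CCCc1cn(C(c2ccccc2)c2cc3cc(Br)ccc3nc2OC)nn1` gives 0.85%, and compound 3 `COc1nc2ccc(Br)cc2cc1C(c1ccccc1)n1cc(-c2ccc(OC(F)(F)F)cc2)nn1` gives 5.8%. Compound 3 has the largest of the three numbers, but its gap to compound 2 and its gap to compound 1 both lie within the scatter, so the three cannot be told apart on these readings.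

Compound 4 `COc1nc2ccc(Br)cc2cc1C(c1ccccc1)n1cc(CCCCCO)nn1` has not been measured yet. It differs from compound 3 in one place: 5-hydroxypentyl in place of 4-(trifluoromethoxy)phenyl on an aromatic carbon.

Among the measured compounds shown here, two measured steps bear on this change, since each swapped a plain chain for the 4-(trifluoromethoxy)phenyl group that now leaves: a number 9.3 percentage points higher from compound 1 to compound 3 (within the scatter) and a number 5 percentage points higher from compound 2 to compound 3 (within the scatter). Neither step rose above the scatter. For the measured compounds named here, compound 4 goes the other way, removing that aryl group and adding a 5-hydroxypentyl chain, which carries one hydrogen-bond donor that none of the measured compounds has. Nothing measured here shows that such a chain shifts the read-out, so the expected step is none beyond the scatter, a number 3.8 percentage points lower from compound 3 to compound 4 (within the scatter). Compound 4 is therefore estimated at 2% in this assay, within a range from -9% to 13%.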

Compound 4, a percentage reported as inhibition, at one concentration (the size of the read-out at that concentration, not a potency): 7.96%
Estimate against measurement, compound 4: 6 percentage points below; low and high end bracket the measured number.
By their numbers in this assay, from the lowest: compounds 1, 2, 3 and 4 (each within the scatter of the next, the first and the last beyond it).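

In this assay, replacing the ring-bearing 4-(trifluoromethoxy)phenyl with the open 5-hydroxypentyl chain on this aromatic carbon of the five-membered ring gives a number 2.2 percentage points higher from compound 3 to compound 4 (within the scatter), so here an aromatic ring and a chain with a hydrogen-bond donor cannot be told apart. Set against the plain chains, the 5-hydroxypentyl compound shows a number 7.1 percentage points higher from compound 2 to compound 4 (within the scatter) and also a number 11.4 percentage points higher from compound 1 to compound 4 (beyond the scatter), the only step beyond the scatter so far, and a modest one that rests on a single pair of compounds. No independent evidence is available to explain this step.

Still open, going by these compounds, is whether that step belongs to the hydroxyl group or to the length of the chain, a question that a plain pentyl chain on the same aromatic carbon could help to settle. Also open, on these data alone, is how a chain carrying an amine or a carboxylic acid would read in this assay, and whether any group in this place can move the number well beyond the scatter.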